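The compounds below may be only part of what the source reports. "The series", "measured", "known", "first", "only" and "open" are said of these compounds alone.

Measured compounds:
- compound 1, `CCN1CCN(S(=O)(=O)CCCN2CCC(CNC(=O)c3cccc4c3OCCO4)CC2)CC1`: 0.0501 nM
- compound 2, `CC(C)N1CCN(S(=O)(=O)CCCN2CCC(CNC(=O)c3cccc4c3OCCO4)CC2)CC1`: 0.0316 nM
- compound 3, `O=C(NCC1CCN(CCCS(=O)(=O)N2CCNCC2)CC1)c1cccc2c1OCCO2`: 0.159 nM

All three share one core and differ only in the group on an amine nitrogen in a ring. In an assay on isolated protein for inhibition of 5-hydroxytryptamine receptor 4 (Homo sapiens) (a lower number here means a stronger inhibitor, a higher number a weaker inhibitor), compound 1 stands in the middle of the three numbers: the step of a 1.6-fold lower number from compound 1 to compound 2 (0.20 log units; within the scatter) is within the scatter, so compound 1 and compound 2 cannot be told apart, while the step of a 3.2-fold higher number from compound 1 to compound 3 (0.50 log units; beyond the scatter) is beyond it, as is a 5.0-fold higher number from compound 2 to compound 3 (0.70 log units; beyond the scatter).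

Compound 4, `O=C(NCC1CCN(CCCS(=O)(=O)N2CCN(S(=O)(=O)c3ccc(F)cc3)CC2)CC1)c1cccc2c1OCCO2`, is not yet measured. It differs from compound 1 in one place: (4-fluorophenyl)sulfonyl in place of ethyl on an amine nitrogen in a ring. The measured steps bear on this only in part. They show that taking the ethyl or isopropyl away, down to hydrogen, costs a modest amount in this assay, and that the two alkyl groups give numbers within the scatter of each other. None of them shows what a large (4-fluorophenyl)sulfonyl group does at this position, so the expectation is wide.

For compound 4 a modest step towards a higher number is expected, a 6.0-fold higher number from compound 1 to compound 4 (0.78 log units; beyond the scatter). Compound 4 is therefore estimated at 0.3 nM, with a range from 0.05 nM to 2 nM.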

Compound 4, inhibition constant: 0.0316 nM
Estimate against measurement, compound 4: 9.5-fold (0.98 log units) above; the whole stated range lies above it.
By their numbers in this assay, from the lowest: compounds 2, 4 and 1 (each within the scatter of the next); then compound 3.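

In this assay, the amine nitrogen in a ring accepts (4-fluorophenyl)sulfonyl, with 10 heavy atoms and one aromatic ring, in place of ethyl, with 2 heavy atoms, with no difference beyond the scatter (a 1.6-fold lower number from compound 1 to compound 4 (0.20 log units; within the scatter)), and the same holds against isopropyl (no change at the digits printed from compound 2 to compound 4 (within the scatter)). Placing this group on the nitrogen that carries only hydrogen in compound 3 gives a step beyond the scatter (a 5.0-fold lower number from compound 3 to compound 4 (0.70 log units; beyond the scatter)), so all three groups shown here, not just small alkyl groups, go with lower numbers than hydrogen. Nothing available explains why such different groups give such close numbers.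

As far as these compounds go, what the fluorine contributes stays open, since phenylsulfonyl or methylsulfonyl on this nitrogen would be needed to tell. From the compounds shown here alone, whether an acetyl or a benzyl group fits the same picture also remains unknown.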